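Adding one carbon to a small side chain

The compounds below may be only part of what the source reports. "The series", "measured", "known", "first", "only" and "open" are said of these compounds alone.

compound 1 `CC(=O)OC1=C(c2cc(C)nc3ccccc23)Oc2cc3ccccc3cc2-n2cccc21` gives 126 nM
compound 2 `CCN(CC)C(=O)OC1=C(c2cc(C)nc3ccccc23)Oc2cc3ccccc3cc2-n2cccc21` gives 4950 nM
compound 3 `CCc1cc(C2=C(OC(C)=O)c3cccn3-c3cc4ccccc4cc3O2)c2ccccc2n1` is not yet measured

Among the measured compounds shown here, in an ADME assay on NIH3T3 cells (Mus musculus) for cytotoxicity, read by MTT assay, with a stated time of 48 h (on this read-out higher numbers stand for weaker inhibition and lower numbers for stronger inhibition), compound 1 gives 126 nM and so holds the lower of the two numbers so far. Compound 3 differs from it at one place: methyl in place of hydrogen on a saturated chain carbon bound to an aromatic carbon so a methyl becomes an ethyl. For the measured compounds named here, the only measured step is a 39-fold higher number from compound 1 to compound 2 (1.59 log units; beyond the scatter) for diethylamino in place of methyl on a carbonyl carbon. That large step sits at a different place and says little here. A step within the scatter, without clear direction, is therefore expected in this assay for this change. The estimated step is a 1.3-fold higher number from compound 1 to compound 3 (0.10 log units; within the scatter) overall. Compound 3 is estimated at 160 nM with an expected range from 55 nM to 480 nM as the likely span.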

Compound 3, half-maximal inhibitory concentration: 540 nM
For compound 3 the middle estimate is 3.4-fold (0.53 log units) below the measured one, outside the stated range (above it).
By their numbers in this assay, from the lowest: compound 1; then compound 3; then compound 2.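

In this assay the change from methyl to ethyl, made on a saturated chain carbon bound to an aromatic carbon, gives a 4.3-fold higher number from compound 1 to compound 3 (0.63 log units; beyond the scatter) and so lies beyond the usual scatter. This position, untouched in the earlier pair, therefore responds to a single added carbon, and the response is toward weaker inhibition. Nothing available here gives a reason for this shift.

As far as these compounds go, whether a longer chain such as propyl would move the number further stays open. So does whether an amine at this position would reverse the shift.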